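The compounds below may be only part of what the source reports. "The series", "measured", "known", "first", "only" and "open" are said of these compounds alone.

Compound 1 `CCN(CC)CCCNC(=O)c1cc(-c2ccccc2)nc2ccccc12`: 45400 nM
Compound 2 `N=C(N)NC(=O)c1cc(-c2ccccc2)nc2ccccc12`: > 250000 nM

In an ADME assay on RD cells (Homo sapiens) for cytotoxicity, read by neutral red uptake, with a stated time of 3 days (on this read-out higher numbers stand for lower toxicity in this test and lower numbers for higher toxicity in this test), compound 2 stands at > 250000 nM, which is a limit of the assay and not a number. Compound 3 `CN(C)CCCNC(=O)c1cc(-c2ccccc2)nc2ccccc12` differs from it in one place: a group of 6 heavy atoms (5 carbon, 1 nitrogen; no ring) in place of a group of 3 heavy atoms (1 carbon, 2 nitrogen; no ring), on an amide-type nitrogen. Within the data shown here, the one measured step that bears on this change is an at least 5.5-fold higher number from compound 1 to compound 2 (0.74 log units; beyond the scatter). The entering group is a smaller relative of the group on compound 1, which gives 45400 nM, so a step of similar size in the opposite direction, beyond the scatter, is expected. The expected change is an at least 4.1-fold lower number from compound 2 to compound 3 (0.61 log units; beyond the scatter). For compound 3 the estimated value is 60000 nM, with a range from 25000 nM to 140000 nM.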

Compound 3, half-maximal cytotoxic concentration: 44900 nM
For compound 3 the middle estimate is 1.3-fold (0.13 log units) above the measured one; measured number inside the range.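

Swapping diethylamino for dimethylamino at the chain end leaves the number in this assay within the scatter (a 1.0-fold lower number from compound 1 to compound 3 (0.00 log units; within the scatter)). Placing 3-(dimethylamino)propyl on the amide-type nitrogen gives a drop beyond the scatter (an at least 5.5-fold lower number from compound 2 to compound 3 (0.74 log units; beyond the scatter)), so the lower toxicity number goes with both amine chains shown. The true size of that drop stays unknown, because compound 2 stands at a limit of the assay and not at a number: the limit of > 250000 nM in this assay, at which 1 of the 3 values shown sits.

Going by these compounds, what a longer chain or a piperidine at the chain end would do remains open. So does the effect of a plain propyl chain with no terminal amine.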